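The source may hold more compounds than are shown below. What is called first, only, known or untested is meant among the compounds shown, and "the series" means these compounds.

Compound 2 `C=CCOC(=O)Nc1ccc([Se]C#N)cc1` and compound 1 `CCCOC(=O)Nc1ccc([Se]C#N)cc1` share one core and differ only in the chain on the saturated carbon bound to an oxygen next to a carbonyl group. In a functional assay on MCF7 cells (Homo sapiens) for cytotoxicity, read by MTT assay, with a stated time of 72 h (a higher number here means a weaker inhibitor of growth, a lower number a stronger inhibitor of growth), compound 1 gives 34400 nM, and compound 2 gives 43100 nM. The step of a 1.3-fold higher number from compound 1 to compound 2 (0.10 log units; within the scatter) lies within the scatter, so the two numbers shown sit together and neither compound can be called the stronger or weaker inhibitor of growth. Compound 3 `CCCCCCOC(=O)Nc1ccc([Se]C#N)cc1` has not yet been measured. It differs from compound 2 by pentyl in place of vinyl on a saturated chain carbon bound to an oxygen next to a carbonyl group. Going by the values given here, the only measured step that touches this same place, a 1.3-fold higher number from compound 1 to compound 2 (0.10 log units; within the scatter), moved the number within the scatter; no measured pair speaks to a chain as long as pentyl. The change from compound 2 to compound 3 is therefore expected to shift this assay little, if at all, and compound 3 is estimated at 30000 nM, with a range from 12000 nM to 80000 nM. That estimate means a step of a 1.4-fold lower number from compound 2 to compound 3 (0.16 log units; within the scatter), expected to stay within the scatter.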

Compound 3, concentration for total growth inhibition: 30500 nM
Estimate against measurement, compound 3: 1.0-fold (0.01 log units) below; low and high end bracket the measured number.
By their numbers in this assay, from the lowest: compounds 3, 1 and 2 (each within the scatter of the next).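

Compound 3 carries the chain well past the propyl and allyl groups of the earlier pair, yet pentyl in place of vinyl, on a saturated chain carbon bound to an oxygen next to a carbonyl group, gives in this assay a step of a 1.4-fold lower number from compound 2 to compound 3 (0.15 log units; within the scatter) and so leaves the two numbers together. The comparison between fully saturated chains reads the same way, with a 1.1-fold lower number from compound 1 to compound 3 (0.05 log units; within the scatter) showing that adding propyl to the end of the chain also separates nothing, so across these three compounds neither chain length nor the double bond of compound 2 gives a readable difference. Nothing at hand explains why these chains sit so close together.

As far as these compounds go, what stays open is whether this position responds to anything other than a plain carbon chain, such as a chain ending in an amine or a carboxylic acid, or a benzyl group. A much longer chain, such as dodecyl, might also shift the number beyond the scatter, and the three compounds shown cannot say where, if anywhere, that would begin.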